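A few compounds are considered here, and "the series" means these few. Any claim that something is new, unique, unknown or untested is made for them only; others in the source may bear on it.

In a functional assay on L02 cells (Homo sapiens) for inhibition, read by Griess assay, with stated times of 1 h and 24 h (on this read-out higher numbers stand for weaker inhibition and lower numbers for stronger inhibition), compound 1 (`CCCc1nn(C)c2c(NCc3ccc(F)cc3)nc(CCc3cccnc3)nc12`) returns < 40000 nM as a limit and not a number. Compound 2 (`CC(C)Nc1nc(/C=C/c2ccccc2)nc2ccsc12`) also returns > 1000000 nM as a limit and not a number. Compound 2 therefore has no exact value and stands at the weak end of the two readings, while compound 1 shares neither its substituents nor a measured step with it.

Compound 3 (`CN1CCN(c2nc(/C=C/c3ccccc3)nc3ccsc23)CC1`) carries 4-methylpiperazin-1-yl in place of isopropylamino on an aromatic carbon next to the ring nitrogen (4-methylpiperazin-1-yl in place of isopropylamino on an aromatic carbon). For the measured compounds named here, no measured pair tests this replacement, so any forecast remains loose. The forecast starts from compound 2 at its limit of > 1000000 nM in the weak direction, which leaves a reported number room to fall only toward stronger inhibition. A moderate move toward stronger inhibition in this assay is therefore expected, estimated as an at least 3.3-fold lower number from compound 2 to compound 3 (0.52 log units; beyond the scatter) with wide uncertainty. A further reading given only as a limit would not be surprising. For compound 3 the expected value is about 300000 nM in an estimated range from 40000 nM to 1000000 nM for this read-out.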

Compound 3, half-maximal inhibitory concentration: 198000 nM
Compound 3: the middle estimate sits 1.5-fold (0.18 log units) above what was measured, and the stated range covers the measured number.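

In this assay, for the compounds shown here, compound 3 gives 198000 nM, the first exact number for this pair, and it gives the change at this position a direction. Putting 4-methylpiperazin-1-yl in place of isopropylamino on the aromatic carbon next to the ring nitrogen produces an at least 5.0-fold lower number from compound 2 to compound 3 (0.70 log units; beyond the scatter). The real size of that step stays open, because compound 2 stands at a limit and not at a number: the limit of > 1000000 nM in this assay, at which 1 of the 3 values shown sits.

The change brings in a six-membered non-aromatic ring and removes the hydrogen-bond donor of isopropylamino, and this single pair cannot tell which of these differences goes with the stronger inhibition. The compounds shown leave open whether morpholin-4-yl or piperazin-1-yl without its methyl, placed on the same carbon, would move the number in the same direction, and compound 1 differs from both compound 2 and compound 3 in more than one place, so it cannot settle the question.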